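Adding a Second Methyl to the Ring Carbon of Compound 2

This account rests on a few compounds, and the source may have more. Where it says the series, first, only, none or still open, it means among the compounds named here.

Compound 1 `CC1(C)OC(Nc2ccccc2)=C(C(=O)O)C1=O`: 44%
Compound 2 `CCOC(=O)C1=C(Nc2ccccc2)OC(C)C1=O`: 61%
Compound 3 `CC1OC(Nc2ccccc2)=C(C(=O)O)C1=O`: 60%

In a functional assay on the whole organism for inhibition, with Rattus norvegicus as the target, at a dose of 100 mg/kg by the intraperitoneal route (on this read-out higher numbers stand for more inhibition at the one dose given (going by the name of the read-out) and lower numbers for less inhibition), compound 2 holds the highest of the three numbers. Compound 3 sits within the scatter of it (a number 1 percentage points lower from compound 2 to compound 3 (within the scatter)), whereas compound 1 stands clearly lower. The not yet measured compound 4 `CCOC(=O)C1=C(Nc2ccccc2)OC(C)(C)C1=O` differs from compound 2 by methyl in place of hydrogen on a saturated ring carbon. For the measured compounds named here, only one measured step bears on this change: a number 16 percentage points higher from compound 1 to compound 3 (beyond the scatter), in which the same kind of methyl was removed from the saturated ring carbon and the number rose. Compound 4 adds that methyl back, so the expected step runs the other way, roughly as large: a number 15 percentage points lower from compound 2 to compound 4 (beyond the scatter). Compound 4 is therefore estimated at 46%, between 30% and 62%.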

Compound 4, a percentage reported as inhibition, in the whole organism at one dose (the size of the read-out at that dose, not a potency): 16%
Beside the measured number, compound 4's estimate is 30 percentage points above it, outside the stated range (below it).
By their numbers in this assay, from the lowest: compound 4; then compound 1; then compounds 3 and 2 (each within the scatter of the next).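

With the ethoxycarbonyl group in place, methyl in place of hydrogen on the saturated ring carbon gives a number 45 percentage points lower from compound 2 to compound 4 (beyond the scatter), so the size of this change depends on what else the core carries: the same change on two cores in this assay, a number 16 percentage points higher (beyond the scatter) from compound 1 to compound 3 and a number 45 percentage points higher (beyond the scatter) from compound 4 to compound 2, 29 percentage points apart, beyond the scatter of two such steps

Once that methyl is present, ethyl in place of hydrogen on the oxygen next to a carbonyl group gives a number 28 percentage points lower from compound 1 to compound 4 (beyond the scatter), unlike on the core of compound 3, so the two places do not act independently: the same change on two cores in this assay, a number 1 percentage points lower (within the scatter) from compound 2 to compound 3 and a number 28 percentage points higher (beyond the scatter) from compound 4 to compound 1, 29 percentage points apart, beyond the scatter of two such steps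

The compounds shown leave open how a longer chain such as propyl, or an amine, would fare on that saturated ring carbon. They also leave open why the two changes combine in this way.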